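The compounds below may be only part of what the source reports. "The series", "measured", "known", "first", "only" and "open" are said of these compounds alone.

Working notes on the arylthiosemicarbazone series, measured in a functional assay on L1210 cells (Mus musculus), with a stated time of 48 h; a higher number here means a weaker inhibitor, a lower number a stronger inhibitor.

Compound 1 `Cc1ccc(CN2C(=O)/C(=N\NC(=S)Nc3ccc(Cl)cc3)c3cc(Cl)ccc32)cc1` gives 9800 nM in this assay. Compound 2 `O=C1/C(=N\NC(=S)Nc2ccc(Cl)cc2)c2cc(Cl)ccc2N1Cc1ccc(Cl)cc1` gives 124000 nM. The two differ in a single place, (chloro in place of methyl on an aromatic carbon), and this change produces a 13-fold higher number from compound 1 to compound 2 (1.10 log units; beyond the scatter). For the measured pair no cause is shown.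

Compound 3 `Cc1ccc(NC(=S)N/N=C2\C(=O)N(Cc3ccc(Cl)cc3)c3ccc(Br)cc32)cc1` gives >= 500000 nM, which is a limit of this assay and not a number. It sits at the limit of >= 500000 nM in this assay, at which 1 of the 3 values shown sits. How the core of compound 3 differs from the core of compound 1 is not broken down here.

Compound 4 `O=C1/C(=N\NC(=S)Nc2ccc(Cl)cc2)c2cc(Br)ccc2N1Cc1ccc(Cl)cc1` is not yet measured in this assay. It differs from compound 3 by chloro in place of methyl on an aromatic carbon, the same change as from compound 1 to compound 2; the wider surroundings read 4-methylbenzyl to 4-chlorobenzyl in the first pair and (4-methylphenyl)amino to (4-chlorophenyl)amino in the second, so it is the same kind of change on a different arm of the shared core. Among the measured compounds shown here, in the one measured instance the change weakened inhibition, as a 13-fold higher number from compound 1 to compound 2 (1.10 log units; beyond the scatter) shows, and compound 3 already stands at a limit, so compound 4 is expected to lie at or beyond that limit as well. The expected step is a step that the limit leaves unreadable from compound 3 to compound 4. For compound 4 the estimate in this assay is 800000 nM, with a likely span from 300000 nM to 3000000 nM, and a reported limit rather than a number is the more probable outcome.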

Compound 4, half-maximal inhibitory concentration: >= 500000 nM
Compound 4 ended at the assay's limit; the forecaster's own chance of this, stated with the estimate: 80%; the middle value lies beyond the limit too.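

Carried to the other arm of the shared core, chloro in place of methyl gives a step that cannot be read, because compound 3 and compound 4 both stand at the same limit of this assay: the limit of >= 500000 nM in this assay, at which 2 of the 4 values shown sit.

Among the compounds shown here, the only readable instance of this change therefore remains a 13-fold higher number from compound 1 to compound 2 (1.10 log units; beyond the scatter), and the second pair neither confirms nor contradicts its direction or size on the (4-methylphenyl)amino arm. Bromo in place of chloro on an aromatic carbon gives an at least 4.0-fold higher number from compound 2 to compound 4 (0.60 log units; beyond the scatter); compound 4 stands at a limit and not a number, so this step shows only a lower bound on the shift, and its true size stays unknown.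

The compounds shown leave open whether the methyl-to-chloro change on the (4-methylphenyl)amino arm has any readable effect on a core where both partners fall inside the measurable range of this assay, as the single readable pair lies on the benzyl arm only. Also open, as far as these compounds go, is whether an amine or a carboxylic acid in place of chloro on the 4-chlorobenzyl arm would bring the bromo compounds back within that range.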